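The source may report more compounds than this note shows. Statements on the series, on what has been measured and on what is new or still open speak of the compounds shown alone.

Of the compounds shown here, two that share a core have been measured in an assay on CHO cells for displacement of a labelled ligand from 5-hydroxytryptamine receptor 1D (Homo sapiens); on this read-out higher numbers stand for weaker inhibition and lower numbers for stronger inhibition. Compound 1 `CN(CC1CCN(CCCc2c[nH]c3ccc(-n4cnnc4)cc23)CC1)C(=O)Nc1ccccc1` gives 5.9 nM. Compound 2 `c1ccc2c(c1)CCC2NC1CCN(CCCc2c[nH]c3ccc(-n4cnnc4)cc23)CC1` gives 8.9 nM in this assay, a number that sits within the usual scatter of the number for compound 1, so the two cannot be told apart on these data. Compound 3 `CN(Cc1ccco1)C1CCN(CCCc2c[nH]c3ccc(-n4cnnc4)cc23)CC1` has not yet been measured in this assay. It differs from compound 2 in one place: ((furan-2-yl)methyl)(methyl)amino in place of (2,3-dihydro-1H-inden-1-yl)amino on a saturated ring carbon. Among the measured compounds shown here, no step between measured compounds that differ in one place is available, so the expectation rests only on the two values and on the nature of the change. The step of a 1.7-fold higher number from compound 2 to compound 3 (0.23 log units; within the scatter) is expected to be a modest move toward a higher number, at the edge of the scatter rather than far beyond it. Compound 3 is estimated at 15 nM in this assay, with a range from 4 nM to 60 nM.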

Compound 3, half-maximal inhibitory concentration: 9.3 nM
The estimate for compound 3 lay 1.6-fold (0.21 log units) above the measured number, and the stated range covers the measured number.
By their numbers in this assay, from the lowest: compounds 1, 2 and 3 (each within the scatter of the next).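

Putting ((furan-2-yl)methyl)(methyl)amino in place of (2,3-dihydro-1H-inden-1-yl)amino on this saturated ring carbon gives a 1.0-fold higher number from compound 2 to compound 3 (0.02 log units; within the scatter) in this assay. This position therefore tolerates a real change of group without a readable shift in the number: a five-membered aromatic ring with one hetero atom replaces a five-membered non-aromatic ring and a six-membered aromatic ring, and the group that enters has 0 hydrogen-bond donors where the group that leaves has 1. Nothing measured here explains why the number holds across this change.

Several features change together in this one step, so a compound carrying (furan-2-yl)methylamino, without the methyl on the nitrogen, would be needed to separate them. Going by these compounds, how far this tolerance reaches also stays open, for example with a much smaller dimethylamino group or with a carboxylic acid at this carbon.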